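The source may report more compounds than this note shows. Statements on the series, on what has been measured and on what is new or still open speak of the compounds shown alone.

Measured compounds:
Compound 1, `COc1ccccc1-n1c(Nc2nc(-c3ccccc3)cs2)n[nH]c1=S`: 300 mg/kg
Compound 2, `COc1ccccc1-n1c(Nc2nc(-c3ccc(Br)cc3)cs2)n[nH]c1=S`: 300 mg/kg

Both compounds were tested in a functional assay on the whole organism (strain Swiss albino) for inhibition, with Mus musculus as the target, with a stated time of 4 h; on this read-out lower numbers stand for an effect already at smaller amounts and higher numbers for an effect only at larger amounts of compound. Compound 2 stands level with compound 1 at the digits shown: the step of no change at the digits printed from compound 1 to compound 2 (within the scatter) lies within the scatter, so the two values cannot be ranked against each other. Compound 2 is therefore the nearest measured neighbour of the compound that follows, and it sits at the same level as everything measured so far.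

Compound 3, `Cc1ccccc1-n1c(Nc2nc(-c3ccc(Br)cc3)cs2)n[nH]c1=S`, has not been measured. It differs from compound 2 in one place: methyl in place of methoxy on an aromatic carbon. Within the data shown here, no measured step in this set bears directly on this change; the only step in hand, from the unsubstituted to the bromo-bearing aryl, showed no change within the scatter, and it concerns a different part of the molecule. The set gives no ground to expect a shift in either direction in this assay, so a step of no size beyond the scatter is expected, no change at the digits printed from compound 2 to compound 3 (within the scatter). Compound 3 is accordingly estimated at 300 mg/kg, with a range from 150 mg/kg to 600 mg/kg.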

Compound 3, minimum effective dose: 30 mg/kg
For compound 3 the middle estimate is 10-fold (1.00 log units) above the measured one, and the stated range ends above it.
By their numbers in this assay, from the lowest: compound 3; then compounds 1 and 2 (each within the scatter of the next).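

In this assay, among these compounds, the group at this place proves to matter: methyl in place of methoxy gives a 10-fold lower number from compound 2 to compound 3 (1.00 log units; beyond the scatter), whereas the only earlier step, a bromo in place of hydrogen elsewhere in the molecule, showed no change at the digits printed from compound 1 to compound 2 (within the scatter). This position, on an aromatic carbon ortho to a large group, is therefore the first place in the series where a single exchange moves the read-out beyond the scatter, and it does so towards an effect at smaller amounts of compound. The exchange swaps methoxy, which counts a hydrogen-bond acceptor, for the smaller methyl, which counts none, but no measurement here says what lies behind the difference in dose.

The compounds shown leave open whether hydrogen, chloro, ethyl or an amine at this same place would give a number like that of methyl, like that of methoxy, or a different one. They also leave open whether 2-methylphenyl would have the same effect on the core of compound 1, which carries no bromo.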